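The source may report more compounds than this note shows. Statements on the series, on what has been measured and on what is new or still open speak of the compounds shown alone.

Of the compounds shown here, two of a shared core have been measured in a physicochemical assay, with a stated time of 180 min, tested at 0.5 mg/mL; a lower number here means less inhibition, a higher number more inhibition at the concentration tested (going by the name of the read-out). Compound 1, with the structure `CC(C)COC(=O)Nc1ccc([Se]C#N)cc1`, gives 27.1% in this assay. Compound 2, with the structure `CCCCCCOC(=O)Nc1ccc([Se][Se]c2ccc(NC(=O)OCCCCCC)cc2)cc1`, gives 16% in this assay. Of these two numbers, that of compound 1 is the higher, and its gap to compound 2 is beyond the usual scatter of the measurement. Among the measured compounds shown here, no step between a pair differing in one place has been measured, so the effect of changing the carbamate chain alone is not known from these data.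

Compound 3, with the structure `CCOC(=O)Nc1ccc([Se]C#N)cc1`, has not yet been measured in this assay. It differs from compound 1 by methyl in place of isopropyl on a saturated chain carbon bound to an oxygen next to a carbonyl group. For the measured compounds named here, since no single-place step is known, the step from compound 1 to compound 3 is expected to be small, with a number 3.1 percentage points lower from compound 1 to compound 3 (within the scatter) not clearly beyond the scatter. Compound 3 is therefore estimated at 24% in this assay, within a range from 12% to 36%.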

Compound 3, a percentage reported as inhibition, at one concentration (the size of the read-out at that concentration, not a potency): 37%
Compound 3: the middle estimate sits 13 percentage points below what was measured, and the stated range ends below it.
By their numbers in this assay, from the lowest: compound 2; then compounds 1 and 3 (each within the scatter of the next).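

In this assay, methyl in place of isopropyl on a saturated chain carbon bound to an oxygen next to a carbonyl group gives a number 9.9 percentage points higher from compound 1 to compound 3 (within the scatter). This first single-place step therefore does not separate the isobutoxy and ethoxy forms of the chain, so removing these two carbons has no effect here that can be told from the scatter. Nothing available bears on the reason for this outcome.

With only this one step, the compounds shown leave open whether any change in this place can move the number beyond the scatter. A benzyl group or a chain ending in an amine at the same place could test this, and the same chain change on a different core would show whether the result carries over.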